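The source may hold more compounds than are shown below. What is called first, only, known or untested is meant among the compounds shown, and "the series" means these compounds.

Working notes on the series, read in a functional assay on A2780 cells (Homo sapiens) for antiproliferative activity, read by MTT assay, with a stated time of 72 h; a higher number here means a weaker inhibitor, a lower number a stronger inhibitor. Compound 1 `O=C(c1cc2ccccc2o1)N1N=C(c2ccccc2)CC1c1ccc([N+](=O)[O-])cc1` gives 4.87 ug/mL, compound 3 `O=C(c1cc2ccccc2o1)N1N=C(c2ccccc2)CC1c1ccc(Cl)cc1` gives 5.13 ug/mL and compound 2 `COc1ccc(C2CC(c3ccccc3)=NN2C(=O)c2cc3ccccc3o2)cc1OC` gives 6.89 ug/mL; compound 1 thus sits within the scatter of both. Compound 4 `COc1ccc(C2CC(c3ccccc3)=NN2C(=O)c2cc3ccccc3o2)cc1` is still unmeasured. It carries methoxy in place of nitro on an aromatic carbon, para to a large group: methoxy in place of nitro on an aromatic carbon. Among the compounds with values here, two measured steps bear on this change. The first, a 1.1-fold higher number from compound 1 to compound 3 (0.02 log units; within the scatter), replaces the same nitro with chloro. The second, a 1.4-fold higher number from compound 1 to compound 2 (0.15 log units; within the scatter), exchanges 4-nitrophenyl for 3,4-dimethoxyphenyl, the closest measured match. Both stay within the scatter, so no step beyond the scatter is expected in this assay. The expected change is a 1.2-fold higher number from compound 1 to compound 4 (0.08 log units; within the scatter). Compound 4 is estimated at 5.9 ug/mL, with an expected range of 3.6 ug/mL to 9.5 ug/mL.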

Compound 4, half-maximal inhibitory concentration: 4.57 ug/mL
Compound 4: middle estimate off by 1.3-fold (0.11 log units), on the high side; low and high end bracket the measured number.
By their numbers in this assay, from the lowest: compounds 4, 1, 3 and 2 (each within the scatter of the next).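

In this assay, methoxy on this aromatic carbon stays within the scatter of nitro (a 1.1-fold lower number from compound 1 to compound 4 (0.03 log units; within the scatter)) and of chloro (a 1.1-fold lower number from compound 3 to compound 4 (0.05 log units; within the scatter)), so a third group at this position leaves the number unmoved. Hydrogen in place of the second methoxy of the 3,4-dimethoxyphenyl group also stays within the scatter (a 1.5-fold lower number from compound 2 to compound 4 (0.18 log units; within the scatter)), so that methoxy does not separate these compounds either. No measurement at hand accounts for this flat response.

Going by these compounds, whether an amine, a carboxylic acid or a longer chain at this position would give a step beyond the scatter remains open. So does any change elsewhere on the shared core.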